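Heteroaryl in place of phenoxy: predicting compound 4

A few compounds are considered here, and "the series" means these few. Any claim that something is new, unique, unknown or untested is made for them only; others in the source may bear on it.

Measured compounds and their numbers in an assay on cells (Endothelial cell) for binding affinity to Endothelin-1 receptor (Sus scrofa); a lower number here means a stronger inhibitor, a higher number a weaker inhibitor:
- compound 1 `COc1cccc(Oc2c(NS(=O)(=O)c3ccc(C(C)(C)C)cc3)ncnc2OCCOc2ccccc2)c1`: 65 nM
- compound 2 `COc1cccc(Oc2c(NS(=O)(=O)c3ccc(C(C)(C)C)cc3)ncnc2OCCOCc2ccccc2)c1`: 170 nM
- compound 3 `COc1cccc(Oc2c(NS(=O)(=O)c3ccc(C(C)(C)C)cc3)ncnc2OCCOc2nccs2)c1`: 12 nM

Compound 1 stands second highest of the three numbers in this assay, so it is the middle compound. Its nearest neighbour is compound 2, reached by the step of a 2.6-fold higher number from compound 1 to compound 2 (0.42 log units; beyond the scatter). Its furthest is compound 3, reached by the step of a 5.4-fold lower number from compound 1 to compound 3 (0.73 log units; beyond the scatter). Between the two outer compounds lies the step of a 14-fold lower number from compound 2 to compound 3 (1.15 log units; beyond the scatter).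

Compound 4 `COc1cccc(Oc2c(NS(=O)(=O)c3ccc(C(C)(C)C)cc3)ncnc2OCCOc2ncc(Br)cn2)c1` is not yet measured. The change from compound 1 is 5-bromopyrimidin-2-yl in place of phenyl on an oxygen on a saturated carbon. Going by the values given here, the step that bears most on it is the one from compound 1 to compound 3, where a five-membered aromatic ring with hetero atoms replaced the phenyl at the same place and the number fell beyond the scatter. The step to compound 2, where only a carbon was inserted, went the other way and was smaller. A six-membered ring with two hetero atoms is therefore expected to lower the number, by a modest step in the same direction as compound 3.

For compound 4 the expected value in this assay is 15 nM, with a range from 5 nM to 50 nM, an estimated step of a 4.3-fold lower number from compound 1 to compound 4 (0.64 log units; beyond the scatter).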

Compound 4, half-maximal inhibitory concentration: 0.051 nM
For compound 4 the middle estimate is 290-fold (2.47 log units) above the measured one; measured number below the stated range.
By their numbers in this assay, from the lowest: compound 4; then compound 3; then compound 1; then compound 2.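

In this assay, the far end of the 2-phenoxyethyl chain proves much more sensitive than the first three compounds suggested: putting 5-bromopyrimidin-2-yl in place of phenyl on this oxygen gives the largest change from compound 1 seen so far (a 1300-fold lower number from compound 1 to compound 4 (3.11 log units; beyond the scatter)). Hetero atoms in the ring do not by themselves account for the size of this step, since the two compounds that carry them still lie far apart (a 240-fold lower number from compound 3 to compound 4 (2.37 log units; beyond the scatter)), and the gap to the benzyl compound is wider still (a 3300-fold lower number from compound 2 to compound 4 (3.52 log units; beyond the scatter)). The compounds shown come with no evidence on why this single change has so large an effect.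

Compound 4 brings in the pyrimidine ring and the bromine together, so the compounds shown cannot divide the gain between them; plain pyrimidin-2-yl, 5-chloropyrimidin-2-yl and 5-methylpyrimidin-2-yl would begin to separate the two. From the compounds shown here alone, it also remains open whether 5-bromopyrimidin-2-yl keeps this effect on a longer chain, such as 3-((5-bromopyrimidin-2-yl)oxy)propyl in place of the 2-((5-bromopyrimidin-2-yl)oxy)ethyl chain.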